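Hydroxy for Iodo on the Sugar Arm of Compound 3

The source may hold more compounds than are shown below. What is called first, only, known or untested is meant among the compounds shown, and "the series" means these compounds.

Of the compounds shown here, three sharing one core have been tested in a functional assay on the whole organism with Mus musculus as the target; on this read-out lower numbers stand for smaller maximal responses and higher numbers for larger maximal responses. Compound 1 `Nc1nc(O)c2c(n1)n(C1OC(CO)[C@@H](O)[C@H]1O)c(=O)n2C/C=C/c1ccccc1` gives 5%. Compound 2 `COc1ccc(Cn2c(=O)n(C3OC(CO)[C@@H](O)[C@H]3O)c3nc(N)nc(O)c32)cc1` gives 14%. Compound 3 `Cn1c(=O)n(C2OC(CI)[C@@H](O)[C@H]2O)c2nc(N)nc(O)c21` gives 4%. All three numbers sit close together, and the gaps from compound 3 to compound 1 and to compound 2 lie within the usual scatter of this assay, so no real ordering among them can be read from these values.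

Within the data shown here, the single step measured between compounds that differ in one place is a number 9 percentage points higher from compound 1 to compound 2 (within the scatter), an exchange at a saturated chain carbon bound to an aromatic nitrogen, far from the part that changes here.

Compound 4 `Cn1c(=O)n(C2OC(CO)[C@@H](O)[C@H]2O)c2nc(N)nc(O)c21` differs from compound 3 by hydroxy in place of iodo on a saturated chain carbon bound to a saturated ring carbon. Compound 1 and compound 2 already carry a hydroxymethyl at that same position, and both give small maximal responses in this assay. Among the measured compounds shown here, the measured step bears only loosely on the change, since it sits elsewhere on the molecule, and no step at the sugar arm itself has been measured. The expected step is therefore a number 4 percentage points higher from compound 3 to compound 4 (within the scatter), a shift not beyond the scatter. Compound 4 is expected to give 8%, within a range from 0% to 25%.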

Compound 4, largest response reached (reported as maximal response), in percent of the reference or control that the assay uses: 100%
Compound 4: the middle estimate sits 92 percentage points below what was measured; the measured number lies above the stated range.
By their numbers in this assay, from the lowest: compounds 3, 1 and 2 (each within the scatter of the next); then compound 4.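

In this assay, hydroxy in place of iodo gives a number 96 percentage points higher from compound 3 to compound 4 (beyond the scatter), so this one exchange on a saturated chain carbon bound to a saturated ring carbon separates a small maximal response from a large one. The hydroxymethyl alone does not secure that large response, since compound 1 and compound 2 carry it too: hydrogen in place of 2-phenylethenyl on a saturated chain carbon bound to an aromatic nitrogen gives a number 95 percentage points higher from compound 1 to compound 4 (beyond the scatter), and hydrogen in place of 4-methoxyphenyl at that same place gives a number 86 percentage points higher from compound 2 to compound 4 (beyond the scatter). The large response therefore depends on both places in this small set, but no measurement shown here explains why either exchange has so large an effect.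

The compounds shown do not tell whether hydroxy itself is needed on the sugar arm, or whether an amine, a methoxy or a fluoro on that same carbon would also give a large response. They also leave open how much can be added at the other place, where something as small as a methyl or an ethyl in place of hydrogen could show how quickly the response falls.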